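This account rests on a few compounds, and the source may have more. Where it says the series, first, only, none or still open, it means among the compounds named here.

Compound 1 `N=C(NCCCc1c[nH]cn1)NCCC(c1ccc(Cl)cc1)c1ccccn1`: 77.6 nM in a functional assay on ileum for antagonist activity at histamine H1 receptor (Cavia porcellus); a higher number here means weaker binding, a lower number tighter binding
Compound 2 `N=C(NCCCc1c[nH]cn1)NCCC(c1ccc(Br)cc1)c1ccccn1`: 120 nM in this assay

Compound 2 sits at one end of these two numbers, yet the step of a 1.5-fold higher number from compound 1 to compound 2 (0.19 log units; within the scatter) stays within the scatter, so the two compounds cannot be told apart in this assay. Compound 3 `N=C(NCCCc1c[nH]cn1)NCCC(c1ccc(C(F)(F)F)cc1)c1ccccn1` differs from compound 2 by trifluoromethyl in place of bromo on an aromatic carbon. Within the data shown here, the only measured step that bears on this change is a 1.5-fold higher number from compound 1 to compound 2 (0.19 log units; within the scatter), a swap of one halogen for another that left the number essentially unchanged; no measured step replaces a halogen with trifluoromethyl. The step from compound 2 to compound 3 is therefore expected to be small, a 1.3-fold higher number from compound 2 to compound 3 (0.10 log units; within the scatter). Compound 3 is estimated at 150 nM, within 55 nM to 420 nM.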

Compound 3, dissociation constant: 282 nM
Compound 3: middle estimate off by 1.9-fold (0.27 log units), on the low side, within the range that was stated.
By their numbers in this assay, from the lowest: compounds 1 and 2 (each within the scatter of the next); then compound 3.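

Trifluoromethyl is the one group shown on this aromatic carbon that shifts the number in this assay beyond the scatter, toward weaker binding, with (a 2.4-fold higher number from compound 2 to compound 3 (0.37 log units; beyond the scatter)) and (a 3.6-fold higher number from compound 1 to compound 3 (0.56 log units; beyond the scatter)). The chloro and bromo compounds alone could not show that this position responds to what sits on it. No measurement here offers a cause for the shift. Still open, from the compounds shown here alone, is how a methyl, a methoxy, an amine or a carboxylic acid at this carbon would compare. Going by these compounds, it is also open whether the same swap would give a similar step on a different core.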